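The source may hold more compounds than are shown below. What is called first, only, known or untested is meant among the compounds shown, and "the series" means these compounds.

Measured in a functional assay on PC-3 cells (Homo sapiens) for antiproliferative activity, read by MTT assay, with a stated time of 72 h; a lower number here means a stronger inhibitor, a higher number a weaker inhibitor:
- Compound 1 `C#CCSc1nc(Sc2nnnn2CCN(C)C)c(C#N)c(-c2ccc(Cl)cc2)n1`: 7170 nM
- Compound 2 `C#CCSc1nc(Sc2nc(C)c(C)s2)c(C#N)c(-c2cc(OC)c(OC)c(OC)c2)n1`: > 20000 nM
- Compound 3 `C=CC(=O)Nc1ccccc1CN(C(=O)Nc1cccc(C(F)(F)F)c1)C1CCN(C(C)CCC)CC1`: 25300 nM

Compound 2 has no number in this assay, only a limit: > 20000 nM. Of the two compounds with numbers, compound 1 reads 7170 nM and compound 3 reads 25300 nM.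

Compound 4 `C#CCSc1nc(Sc2nc[nH]n2)c(C#N)c(-c2cc(OC)c(OC)c(OC)c2)n1` differs from compound 2 in one place: 1H-1,2,4-triazol-3-yl in place of 4,5-dimethyl-1,3-thiazol-2-yl on a sulfur. On a sulfur whose other neighbour is an aromatic carbon, 1H-1,2,4-triazol-3-yl stands in place of 4,5-dimethyl-1,3-thiazol-2-yl. For the measured compounds named here, no pair of measured compounds shows this change or any other single change.

The expected step of a number no higher from compound 2 to compound 4 (the limit leaves the size open) in this assay is none beyond the scatter, with neither direction favoured. This expectation rests on compound 2, whose reading > 20000 nM is a limit. The estimate for compound 4 is 20000 nM, expected to fall in the range 7000 nM to 60000 nM.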

Compound 4, half-maximal inhibitory concentration: > 20000 nM
Compound 4 ended at the assay's limit (the forecaster's own chance of this, stated with the estimate: 55%); the middle value lies on the limit itself.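

In this assay, for the compounds shown here, compound 2 and compound 4 both stand as limits, so no step between them can be read: the limit of > 20000 nM in this assay, at which 2 of the 4 values shown sit. The compounds shown leave open whether 1H-1,2,4-triazol-3-yl in place of 4,5-dimethyl-1,3-thiazol-2-yl on a sulfur changes the reading at all, and in which direction.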